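Chain extension from compound 1 to compound 4

This account rests on a few compounds, and the source may have more. Where it says the series, first, only, none or still open, it means among the compounds named here.

Among the compounds with values here, in a functional assay on SK-MEL-28 cells (Homo sapiens) for inhibition, read by colorimetric assay and MTT assay, with a stated time of 72 h (a higher number here means a weaker inhibitor, a lower number a stronger inhibitor), compound 1 (`C=CCCCCOc1ccccc1-c1cnc(OCCC=C)n1C`) gives 17000 nM and holds the lowest of the three numbers so far. Compound 2 (`C=CCCCCOc1ccc(C)cc1-c1cnc(OCCC=C)n1C`) gives 83000 nM in this assay and compound 3 (`C=CCCCCOc1ccc(OC)cc1-c1cnc(OCCC=C)n1C`) gives 62000 nM there. Compound 4 (`C=CCCCCOc1ccccc1-c1cnc(OCCCCC=C)n1C`) keeps the core of compound 1 and alters one chain. The change is but-3-en-1-yl in place of vinyl on a saturated chain carbon, two bonds along the chain from an oxygen on an aromatic ring and it also reads as (but-3-en-1-yl)oxy to (hex-5-en-1-yl)oxy.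

Within the data shown here, no measured step touches this chain. The nearest evidence lies on an aromatic carbon: methyl gives a 4.9-fold higher number from compound 1 to compound 2 (0.69 log units; beyond the scatter) and methoxy gives a 3.6-fold higher number from compound 1 to compound 3 (0.56 log units; beyond the scatter) while the swap of the two gives a 1.3-fold lower number from compound 2 to compound 3 (0.13 log units; within the scatter) within the scatter. These steps set only a rough scale for one change to this series and give no direction for a chain change. A step no larger than those modest ones is therefore expected in this assay with its direction left open. The estimated step is a 1.2-fold higher number from compound 1 to compound 4 (0.07 log units; within the scatter) at the middle of the range. Compound 4 is expected at 20000 nM with an estimated range from 7000 nM to 60000 nM in this series.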

Compound 4, half-maximal inhibitory concentration: 5000 nM
Beside the measured number, compound 4's estimate is 4.0-fold (0.60 log units) above it; the whole stated range lies above it.
By their numbers in this assay, from the lowest: compound 4; then compound 1; then compounds 3 and 2 (each within the scatter of the next).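

The chain on the imidazole-free reading of this series is not needed here: the position named by (but-3-en-1-yl)oxy tolerates extension to (hex-5-en-1-yl)oxy, and in this assay the change gives a 3.4-fold lower number from compound 1 to compound 4 (0.53 log units; beyond the scatter). Within the data shown here, that direction differs from the two changes on the aromatic carbon, a 4.9-fold higher number from compound 1 to compound 2 (0.69 log units; beyond the scatter) and a 3.6-fold higher number from compound 1 to compound 3 (0.56 log units; beyond the scatter), so this chain is the first place where a change lowers the number beyond the scatter. No measurement on hand accounts for the shift.

From the compounds shown here alone, whether a still longer chain such as oct-7-en-1-yl lowers the number further, or a saturated hexyl chain does the same, remains open. Also open, going by these compounds, is whether methyl or methoxy on the aromatic carbon raises the number on the core of compound 4 as it does on compound 1.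

Correction to the opening sentence, which should read without its first clause: the position named by (but-3-en-1-yl)oxy tolerates extension to (hex-5-en-1-yl)oxy.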